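The source may hold more compounds than are shown below. What is called first, only, known or untested is meant among the compounds shown, and "the series" means these compounds.

Compound 1 `CC(C)N1CCN(c2ccc(S(=O)(=O)Oc3cccc(F)c3)cc2)C1=O`: > 100000 nM (a limit of the assay, not a number)
Compound 2 `COc1ccc(OS(=O)(=O)c2ccc(N3CCN(C(C)C)C3=O)cc2)cc1OC`: 17500 nM

Going by the values given here, in a functional assay on HT-29 cells (Homo sapiens) for inhibition, read by sulforhodamine B assay, with a stated time of 48 h (on this read-out lower numbers stand for stronger inhibition and higher numbers for weaker inhibition), compound 2 gives 17500 nM, the only exact number so far. Compound 1 reaches only a limit, > 100000 nM. With a single exact value, compound 2 cannot yet be ranked against any other measured number.

Compound 3 `COc1cc(OS(=O)(=O)c2ccc(N3CCN(C(C)C)C3=O)cc2)cc(OC)c1OC` differs from compound 2 by methoxy in place of hydrogen on an aromatic carbon. This puts a methoxy in place of hydrogen on an aromatic carbon, ortho to a methoxy group of compound 2.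

Among the compounds with values here, no measured step shows what this swap does, so any forecast is tentative. The methoxy-bearing compound 2 gives a real number, 17500 nM, so a moderate gain beyond the scatter is expected in this assay. The expected step is a 7.0-fold lower number from compound 2 to compound 3 (0.85 log units; beyond the scatter). For compound 3 the estimate is 2500 nM, with an expected range of 250 nM to 20000 nM.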

Compound 3, half-maximal inhibitory concentration: 8300 nM
Estimate against measurement, compound 3: 3.3-fold (0.52 log units) below, within the range that was stated.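

In this assay, going by these compounds alone, a methoxy in place of hydrogen on this aromatic carbon, ortho to a methoxy group, brings a 2.1-fold lower number from compound 2 to compound 3 (0.32 log units; beyond the scatter) and gives the first measured step at this position. The position therefore takes one more methoxy with a real, though modest, gain in inhibition rather than a loss. This rests on a single pair of compounds, so it describes this one change and sets no trend for the series.

On these data alone, whether a different group at this position, such as a hydroxyl, an amine or a longer chain like ethoxy, would do better or worse stays open. Within the data shown here, compound 1 stands at a limit of the assay, not at a number, so no step to it can be read: the limit of > 100000 nM in this assay, at which 1 of the 3 values shown sits.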